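Removing the fluoro from compound 3: an expected clearance

The source may hold more compounds than are shown below. What is called first, only, known or untested is meant among the compounds shown, and "the series" means these compounds.

Measured compounds so far:
- Compound 1, `COc1ccccc1C(=O)Nc1[nH]nc(-c2ccccn2)c1C1CC1`: > 100 mL.min-1.g-1
- Compound 2, `O=C(Nc1cc(-c2ccccn2)n[nH]1)N1CCC(Oc2ccccc2)CC1`: 98.5 mL.min-1.g-1
- Compound 3, `O=C(Nc1cc(-c2ccccn2)n[nH]1)N1CCC(c2ccc(F)cc2)CC1`: 272 mL.min-1.g-1

All three share a core and were tested in an ADME assay on liver (Mesocricetus auratus) for metabolic stability, using microsomes; on this read-out lower numbers stand for slow clearance and higher numbers for fast clearance. For compound 1 the result is only a limit, (the limit of > 100 mL.min-1.g-1 in this assay, at which 1 of the 3 values shown sits), not a number. Among the measured compounds shown here, of the two compounds with a number, compound 3 stands highest; the one step measured between them, a 2.8-fold higher number from compound 2 to compound 3 (0.44 log units; beyond the scatter), is modest but beyond the scatter.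

The next compound, compound 4, `O=C(Nc1cc(-c2ccccn2)n[nH]1)N1CCC(c2ccccc2)CC1`, differs from compound 3 in one place: hydrogen in place of fluoro on an aromatic carbon. For the measured compounds named here, none of the measured steps concerns this kind of change; the only measured step swaps a 4-fluorophenyl for a phenoxy on a saturated ring carbon, which is a different move, so no direct guide exists. The removal of a single fluorine is a small change, and without a comparable step the expectation is a step of a 1.1-fold higher number from compound 3 to compound 4 (0.04 log units; within the scatter), that is, no shift beyond the scatter in either direction. Compound 4 is therefore expected to give 300 mL.min-1.g-1 in this assay, with a likely range from 150 mL.min-1.g-1 to 600 mL.min-1.g-1.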

Compound 4, intrinsic clearance in microsomes: 216 mL.min-1.g-1
The estimate for compound 4 lay 1.4-fold (0.14 log units) above the measured number; measured number inside the range.
By their numbers in this assay, from the lowest: compound 2; then compounds 4 and 3 (each within the scatter of the next).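

In this assay, replacing the fluoro on the aromatic carbon with hydrogen gives a 1.3-fold lower number from compound 3 to compound 4 (0.10 log units; within the scatter), so at this place, para to a large group, the data do not separate fluoro from hydrogen. The change on the saturated ring carbon can now also be read without any fluoro: phenyl in place of phenoxy gives a 2.2-fold higher number from compound 2 to compound 4 (0.34 log units; beyond the scatter), so the modest gap seen earlier with the 4-fluorophenyl group is still there once the fluoro has gone. Nothing measured here accounts for either step.

Only fluoro and hydrogen are shown at this aromatic carbon, so it remains open whether a methoxy group, a nitrile or an amine there would leave the clearance where it is or move it beyond the scatter. On the saturated ring carbon, only the phenoxy, phenyl and 4-fluorophenyl groups are shown, so it also remains open whether a benzyl group there would give a number closer to that of compound 2 or that of compound 4.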